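Repositioning a Hydroxyphenyl Group on a Shared Core

This account rests on a few compounds, and the source may have more. Where it says the series, first, only, none or still open, it means among the compounds named here.

Compound 1 `Oc1cccc(-c2cc(-c3ccccc3OC(F)(F)F)cc(-c3cccc(O)c3)n2)c1` and compound 2 `Oc1cccc(-c2cc(-c3ccc(OC(F)(F)F)cc3)cc(-c3cccc(O)c3)n2)c1` are built from the same atoms joined differently; the difference between the two cores is not broken down here. In a functional assay on T47D cells (Homo sapiens) for inhibition (a lower number here means a stronger inhibitor, a higher number a weaker inhibitor), compound 1 gives 7950 nM, and compound 2 gives 9820 nM. Compound 3 `Oc1ccc(-c2cc(-c3ccccc3OC(F)(F)F)cc(-c3cccc(O)c3)n2)cc1` arises from compound 1 by a single change, (4-hydroxyphenyl in place of 3-hydroxyphenyl on an aromatic carbon), and in this assay compound 3 gives 7300 nM; the resulting step of a 1.1-fold lower number from compound 1 to compound 3 (0.04 log units; within the scatter) lies within the scatter. Compound 4 `Oc1ccc(-c2cc(-c3ccc(OC(F)(F)F)cc3)cc(-c3cccc(O)c3)n2)cc1` has not yet been measured; it arises from compound 2 by the same change, (4-hydroxyphenyl in place of 3-hydroxyphenyl on an aromatic carbon). Compound 4 is expected to show a step of a 1.1-fold lower number from compound 2 to compound 4 (0.04 log units; within the scatter) in this assay because the earlier step of a 1.1-fold lower number from compound 1 to compound 3 (0.04 log units; within the scatter) stayed within the scatter. In this assay compound 4 is therefore estimated at 9000 nM, most likely between 4500 nM and 18000 nM.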

Compound 4, half-maximal inhibitory concentration: 18900 nM
Compound 4: middle estimate off by 2.1-fold (0.32 log units), on the low side; measured number above the stated range.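

On the core of compound 2, 4-hydroxyphenyl in place of 3-hydroxyphenyl gives a 1.9-fold higher number from compound 2 to compound 4 (0.28 log units; within the scatter) in this assay, so this step cannot be told apart from the ordinary spread of repeated measurements. Set beside the earlier step, it gives no sign that the two cores respond differently to this change: the same change on two cores in this assay, a 1.1-fold lower number (0.04 log units; within the scatter) from compound 1 to compound 3 and a 1.9-fold higher number (0.28 log units; within the scatter) from compound 2 to compound 4, 2.1-fold (0.32 log units) apart, within the scatter of two such steps

This does not prove that the change behaves identically on both cores, since a small real difference could hide in the scatter, and two cores say nothing about others in the series. Still open, going by these compounds, is whether any swap on this hydroxyphenyl ring would produce a step beyond the scatter. An amine or a carboxylic acid in place of the hydroxyl would be one such test.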